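This account rests on a few compounds, and the source may have more. Where it says the series, first, only, none or still open, it means among the compounds named here.

Measured in an ADME assay on cells (Hepatocyte, Mus musculus) for metabolic stability, with a stated time of 30 min; a lower number here means that less of the compound is left, a higher number that more of the compound is left:
compound 1 `NC1CCC(CN2CCN(c3cc(=O)c4cc(C(F)(F)F)cc([N+](=O)[O-])c4s3)CC2)CC1` gives 107%
compound 2 `CS(=O)(=O)NC1CCC(CN2CCN(c3cc(=O)c4cc(C(F)(F)F)cc([N+](=O)[O-])c4s3)CC2)CC1` gives 111%
compound 3 `O=c1cc(N2CCN(CC3CCCCC3)CC2)sc2c(NO)cc(C(F)(F)F)cc12` gives 47.8%

Compound 2 stands level with compound 1 within the scatter, while compound 3 lies lower, beyond the scatter. The next structure, compound 4 `O=C(OC1CCC(CN2CCN(c3cc(=O)c4cc(C(F)(F)F)cc([N+](=O)[O-])c4s3)CC2)CC1)c1ccncc1`, carries ((pyridin-4-yl)carbonyl)oxy in place of methanesulfonamido on a saturated ring carbon. For the measured compounds named here, only one measured step touches this part of the molecule: a number 4 percentage points higher from compound 1 to compound 2 (within the scatter). It is small, but it adds to the amine nitrogen and does not replace it. Going by the values given here, no measured compound carries the entering group, so this step guides only loosely. Compound 2 already reads 111%, which leaves little room upward, and compound 3 at 47.8% shows that a far lower number occurs in this family, although it differs in more than one place. A moderate fall in this assay is therefore expected, with a wide margin. The expected change is a number 36 percentage points lower from compound 2 to compound 4 (beyond the scatter). For compound 4 the estimated value is 75%, with an expected range of 35% to 105%.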

Compound 4, percent of the compound remaining: 1.4%
Compound 4: the middle estimate sits 73.6 percentage points above what was measured; the measured number lies below the stated range.
By their numbers in this assay, from the lowest: compound 4; then compound 3; then compounds 1 and 2 (each within the scatter of the next).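

In this assay, the saturated ring carbon turns out to be a place where the choice of group can matter greatly: the ((pyridin-4-yl)carbonyl)oxy group gives a number 109.6 percentage points lower from compound 2 to compound 4 (beyond the scatter) and a number 105.6 percentage points lower from compound 1 to compound 4 (beyond the scatter), whereas the earlier change there gave only a number 4 percentage points higher from compound 1 to compound 2 (within the scatter). Amino and methanesulfonamido, both attached through nitrogen, thus read level, while the group attached through oxygen stands far apart from both. Nothing available here explains this fall.

The change swaps the attaching atom and brings in the pyridine ring at once, so the compounds shown do not tell which of the two goes with the low number. A hydroxyl on the same ring carbon, or an amide carrying the same pyridin-4-yl carbonyl on nitrogen, would begin to separate the two.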